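Tetrazole for Carboxylic Acid at the Chain End

The source may hold more compounds than are shown below. What is called first, only, known or untested is meant among the compounds shown, and "the series" means these compounds.

Measured so far:
compound 1, `CCc1cc(C(C)=O)c(O)cc1OCCCCCC(C)(C)C#N`, gives 17%
compound 2, `CCc1cc(C(C)=O)c(O)cc1OCCCCCCCC(C)(C)C#N`, gives 6%
compound 3, `CCc1cc(C(C)=O)c(O)cc1OCCCCCC(C)(C)C(=O)O`, gives 20%

In an assay on isolated protein for binding affinity to leukotriene B4 receptor (Homo sapiens), tested at 0.1 uM (a lower number here means less inhibition, a higher number more inhibition at the concentration tested (going by the name of the read-out)), compound 3 stands highest of the three numbers, though its gap to compound 1 is within the scatter, while compound 2 lies beyond the scatter below it, as a number 14 percentage points higher from compound 2 to compound 3 (beyond the scatter) shows. Compound 4, `CCc1cc(C(C)=O)c(O)cc1OCCCCCCC(C)(C)c1nnn[nH]1`, is not yet measured. It carries 2-(1H-tetrazol-5-yl)-2-methylpropyl in place of 1-carboxy-1-methylethyl on a saturated chain carbon, five bonds along the chain from an oxygen on an aromatic ring. Within the data shown here, two measured steps bear on this. Exchanging cyano for carboxy changed little, a number 3 percentage points higher from compound 1 to compound 3 (within the scatter), so the acid-like end itself seems not decisive here. Lengthening the end group from 1-cyano-1-methylethyl to 3-cyano-3-methylbutyl, however, lowered inhibition modestly, a number 11 percentage points lower from compound 1 to compound 2 (beyond the scatter). Among the measured compounds shown here, since compound 4 also carries a longer end group than compound 3, a modest drop is expected, a number 10 percentage points lower from compound 3 to compound 4 (within the scatter), with no direct precedent for the tetrazole itself. Compound 4 is therefore estimated at 10%, within the range 0% to 28%.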

Compound 4, a percentage reported as inhibition, at one concentration (the size of the read-out at that concentration, not a potency): 13%
Compound 4: middle estimate off by 3 percentage points, on the low side; low and high end bracket the measured number.
By their numbers in this assay, from the lowest: compounds 2, 4, 1 and 3 (each within the scatter of the next, the first and the last beyond it).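

In this assay, putting 2-(1H-tetrazol-5-yl)-2-methylpropyl in place of 1-carboxy-1-methylethyl at this place on the chain gives a step that stays inside the scatter, a number 7 percentage points lower from compound 3 to compound 4 (within the scatter), and the steps from the two nitriles do the same, a number 4 percentage points lower from compound 1 to compound 4 (within the scatter) and a number 7 percentage points higher from compound 2 to compound 4 (within the scatter). The tetrazole compound therefore cannot be separated from any of the other three compounds, even though the step between the longer nitrile and the carboxylic acid is printed as beyond the scatter. No measurement shown here accounts for these numbers.

Still open, from the compounds shown here alone, is what 1-(1H-tetrazol-5-yl)-1-methylethyl, the tetrazole end group without the extra chain carbons, would give on the same core. Also open, going by these compounds, is how a primary amide or an amine would compare at the chain end.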